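A few compounds are considered here, and "the series" means these few. Any claim that something is new, unique, unknown or untested is made for them only; others in the source may bear on it.

Compound 1 `CC1CN(C(=O)c2ccc(-c3ccc(NC(=O)Nc4ccc(Cl)c(C(F)(F)F)c4)cc3)cc2)CC(C)O1`, compound 2 `CC(NC(=O)c1ccc(-c2ccc(NC(=O)Nc3cc(C(F)(F)F)ccc3Cl)cc2)cc1)c1ccccc1` and compound 3 `C/C(=C\C(=O)N1CC(C)OC(C)C1)c1ccc(NC(=O)Nc2ccc(Cl)c(C(F)(F)F)c2)cc1` have been measured in a functional assay on HT-29 cells (Homo sapiens) for inhibition, read by MTT assay, with a stated time of 120 h; a higher number here means a weaker inhibitor, a lower number a stronger inhibitor. In this assay compound 1 gives 2050 nM, compound 2 gives 6570 nM, and compound 3 gives 26200 nM. Compound 2 therefore stands second highest of the three numbers: its nearest neighbour is compound 1, whose lower number lies beyond the scatter, and its furthest is compound 3, whose higher number also lies beyond the scatter. Compound 4 `CC(NC(=O)c1ccc(-c2ccc(NC(=O)Nc3ccc(Cl)c(C(F)(F)F)c3)cc2)cc1)c1ccccc1` has not yet been measured in this assay. It differs from compound 2 by 4-chloro-3-(trifluoromethyl)phenyl in place of 2-chloro-5-(trifluoromethyl)phenyl on an amide-type nitrogen, so the two hold the same atoms joined differently, and compound 4 carries the 4-chloro-3-(trifluoromethyl)phenyl group found in compound 1 and compound 3. Going by the values given here, no measured pair differs in only this one place, so the size of the step is not known from the data. Because compound 1 gives 2050 nM with this same group, a lower number is expected for compound 4. The expected step is a 2.6-fold lower number from compound 2 to compound 4 (0.42 log units; beyond the scatter), toward a lower number. Compound 4 is estimated at 2500 nM, with a range from 800 nM to 8000 nM.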

Compound 4, half-maximal inhibitory concentration: 5960 nM
The estimate for compound 4 lay 2.4-fold (0.38 log units) below the measured number; low and high end bracket the measured number.
By their numbers in this assay, from the lowest: compound 1; then compounds 4 and 2 (each within the scatter of the next); then compound 3.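

In this assay, 4-chloro-3-(trifluoromethyl)phenyl in place of 2-chloro-5-(trifluoromethyl)phenyl on the amide-type nitrogen gives a 1.1-fold lower number from compound 2 to compound 4 (0.04 log units; within the scatter), so with (1-phenylethyl)amino held fixed, this assay does not tell these two arrangements of the same atoms apart. With 4-chloro-3-(trifluoromethyl)phenyl held fixed, the change on the carbonyl carbon gives a 2.9-fold higher number from compound 1 to compound 4 (0.46 log units; beyond the scatter), so 2,6-dimethylmorpholin-4-yl and (1-phenylethyl)amino do separate. Nothing available accounts for either step. Still open, as far as these compounds go, is whether the two aryl groups also stay level when the carbonyl carbon carries 2,6-dimethylmorpholin-4-yl. Also open, from the compounds shown here alone, is whether a pyridyl ring or a phenyl ring carrying a nitrile on the amide-type nitrogen would separate from them.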